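Trifluoromethyl to fluoro: clearance notes on compound 4

A few compounds are considered here, and "the series" means these few. Any claim that something is new, unique, unknown or untested is made for them only; others in the source may bear on it.

Measured in an ADME assay on the whole organism for pharmacokinetics, with Rattus norvegicus as the target, at a dose of 3 mg/kg by the intravenous route; a lower number here means slower removal, a higher number faster removal of the compound:
- compound 1 `COC(=O)N[C@H](C(=O)N1CCC[C@H]1C(=O)Nc1ccc([C@H]2CC[C@H](c3ccc(NC(=O)[C@@H]4CCCN4C(=O)[C@@H](NC(=O)OC)C(C)C)cc3)N2c2ccc(C(F)(F)F)cc2)cc1)C(C)C`: 4.83 mL/min/kg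
- compound 2 `COC(=O)N[C@H](C(=O)N1CCC[C@H]1C(=O)Nc1ccc([C@H]2CC[C@H](c3ccc(NC(=O)[C@@H]4CCCN4C(=O)[C@@H](NC(=O)OC)C(C)(C)C)cc3)N2c2ccc(F)cc2)cc1)C(C)(C)C`: 1.67 mL/min/kg
- compound 3 `COC(=O)N[C@H](C(=O)N1CCC[C@H]1C(=O)Nc1ccc([C@H]2CC[C@H](c3ccc(NC(=O)[C@@H]4CCCN4C(=O)[C@@H](NC(=O)OC)[C@@H](C)OC)cc3)N2c2ccc(F)cc2)cc1)[C@@H](C)OC`: 45 mL/min/kg

Compound 1 stands in the middle of the three, with compound 2 lower and compound 3 higher, both gaps beyond the scatter.

Compound 4 `COC(=O)N[C@H](C(=O)N1CCC[C@H]1C(=O)Nc1ccc([C@H]2CC[C@H](c3ccc(NC(=O)[C@@H]4CCCN4C(=O)[C@@H](NC(=O)OC)C(C)C)cc3)N2c2ccc(F)cc2)cc1)C(C)C` is still unmeasured. It keeps the structure of compound 1 except for fluoro in place of trifluoromethyl on an aromatic carbon, para to a large group: fluoro in place of trifluoromethyl on an aromatic carbon.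

Among the measured compounds shown here, no measured pair isolates this change. Compounds 2 and 3 also carry the 4-fluorophenyl but differ from compound 4 elsewhere, and their values lie far apart: compound 2 gives 1.67 mL/min/kg and compound 3 gives 45 mL/min/kg. The fluoro alone therefore sets no level, and compound 1 at 4.83 mL/min/kg remains the closest guide.

The expected change is small and within the scatter, slightly upward if anything: a 1.2-fold higher number from compound 1 to compound 4 (0.09 log units; within the scatter). For compound 4 the estimated clearance is 6 mL/min/kg, with an expected range from 2 mL/min/kg to 16 mL/min/kg.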

Compound 4, clearance: 2.17 mL/min/kg
For compound 4 the middle estimate is 2.8-fold (0.44 log units) above the measured one; the range from low to high includes it.
By their numbers in this assay, from the lowest: compounds 2 and 4 (each within the scatter of the next); then compound 1; then compound 3.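

In this assay, among the compounds shown here, the change from trifluoromethyl to fluoro gives a 2.2-fold lower number from compound 1 to compound 4 (0.35 log units; beyond the scatter), the first step that isolates this place on the shared core. It shows that the substituent on this aromatic carbon is not silent in this read-out, and that the smaller group, fluoro, goes with slower removal when the rest of compound 1 is held fixed. No measurement at hand accounts for the step, so its origin remains unexplained.

With a single matched pair, one step gives a direction for these two groups only and no trend with substituent size or type. From the compounds shown here alone, how a chloro, a nitrile, a methoxy group or an amine at the same place would read in this assay remains open.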